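The source may hold more compounds than are shown below. What is called first, only, known or untested is meant among the compounds shown, and "the series" means these compounds.

Measured in a physicochemical assay for solubility, measured as thermodynamic solubility, with a stated time of 24 h, at pH 6.8 (on this read-out higher numbers stand for higher solubility and lower numbers for lower solubility), each value a limit:
- Compound 1 `Cc1cc(C)c2cc(C(=O)NC3CCCCC3)[nH]c2c1`: < 4000 nM
- Compound 2 `Cc1cc(C)c2cc(C(=O)N[C@@H]3CCCC[C@@H]3C)[nH]c2c1`: < 4000 nM
- Compound 3 `C[C@H]1CCCC[C@H]1NC(=O)c1cc2c(F)cc(F)cc2[nH]1`: < 4000 nM

Compound 3 has only a limit and no number in this assay. The same holds across the series: the limit of < 4000 nM in this assay, at which 3 of the 3 values shown sit. Compound 4 `C[C@H]1CC[C@H](NC(=O)c2cc3c(F)cc(F)cc3[nH]2)CC1` carries the change (4-methylcyclohexyl in place of 2-methylcyclohexyl on an amide-type nitrogen), with 4-methylcyclohexyl in place of 2-methylcyclohexyl on an amide-type nitrogen. For the measured compounds named here, the one measured step bearing on this, methyl in place of hydrogen on a saturated ring carbon, is a step that the two limits leave unreadable from compound 1 to compound 2. No step beyond the scatter is expected in this assay, because a step that the two limits leave unreadable from compound 1 to compound 2 offers no readable size to carry over. The expected step is a step that the limit leaves unreadable from compound 3 to compound 4. For compound 4 the estimate is 2000 nM, with an expected range of 500 nM to 5000 nM.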

Compound 4, solubility: < 4000 nM
Compound 4: no number, only a limit; the forecaster's own chance of this, stated with the estimate: 85%; the middle value lies beyond the limit too.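

No step can be read between compound 3 and compound 4 in this assay, since each carries only a limit. The compounds shown leave open whether 2-methylcyclohexyl and 4-methylcyclohexyl differ at all on this read-out.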